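Trimming the chain on the ring nitrogen of compound 2

A few compounds are considered here, and "the series" means these few. Any claim that something is new, unique, unknown or untested is made for them only; others in the source may bear on it.

Compound 1 `CCOC(=O)c1cn(C)c2cc(Cl)ccc2c1=O` and compound 2 `CCCCn1cc(C(=O)OCC)c(=O)c2ccc(Cl)cc21` share one core and differ only in the chain on the aromatic nitrogen. In a functional assay on HEp-2 cells (Homo sapiens) for cytotoxicity, read by MTT assay, with a stated time of 24 h (a higher number here means a weaker inhibitor, a lower number a stronger inhibitor), compound 1 gives 25000 nM, and in this assay compound 2 gives 35500 nM. Among these two numbers compound 2 holds the higher one, but the gap a 1.4-fold higher number from compound 1 to compound 2 (0.15 log units; within the scatter) is within the scatter, so no order between them can be read. Compound 3 `CCOC(=O)c1cn(CC)c2cc(Cl)ccc2c1=O` arises from compound 2 by the change (hydrogen in place of ethyl on a saturated chain carbon, two bonds along the chain from an aromatic nitrogen). Among the measured compounds shown here, the only step that bears on it is a 1.4-fold higher number from compound 1 to compound 2 (0.15 log units; within the scatter), which lengthened the same chain from methyl to butyl without moving the number beyond the scatter; the shortening to ethyl is therefore expected to give a step of a 1.2-fold lower number from compound 2 to compound 3 (0.07 log units; within the scatter), that is none beyond the scatter. Compound 3 is estimated at 30000 nM, with a range from 15000 nM to 60000 nM.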

Compound 3, half-maximal inhibitory concentration: > 50000 nM
Compound 3 gave a limit, no number; the forecaster's own chance of this, stated with the estimate: 10%; at least 1.6-fold (0.22 log units) between middle value and limit.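

With the ethyl chain on the aromatic nitrogen, compound 3 gives a limit of the assay and not a number in this assay: the limit of > 50000 nM in this assay, at which 1 of the 3 values shown sits.

The steps to it are an at least 1.4-fold higher number from compound 2 to compound 3 (0.14 log units; that floor lies within the scatter) and an at least 2.0-fold higher number from compound 1 to compound 3 (0.30 log units; that floor lies within the scatter), so both floors stay inside the scatter and fix no order among the three compounds. Compound 1 and compound 2 alone had made this position look flat for a change of chain, whereas compound 3 shows that this reading can no longer be taken as settled, though the limit does not overturn it.

Whether the ethyl chain truly stands apart from methyl and butyl stays open, as no number lies behind the limit of compound 3. Also open, on these data alone, is how a longer chain, or a chain carrying an amine or a carboxylic acid, would read on this nitrogen.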